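Taking the bromo group off compound 3

The source may report more compounds than this note shows. Statements on the series, on what has been measured and on what is new or still open speak of the compounds shown alone.

In an ADME assay on MDBK cells (Bos taurus) for cytotoxicity, read by MTT assay, with a stated time of 72 h (a higher number here means that more compound is tolerated, a lower number that less compound is tolerated), compound 3 `Cc1ccc(-c2nn(-c3ccccc3)cc2CNc2ccc(Br)cc2)cc1` gives > 100000 nM, a limit of the assay and not a number. Compound 1 `Brc1ccc(NCc2cn(-c3ccccc3)nc2-c2ccccc2)cc1` gives > 100000 nM, also a limit. Compound 2 `Cc1ccc(NCc2cn(-c3ccccc3)nc2-c2ccc(C)cc2)cc1` gives > 100000 nM, again a limit. The evidence so far is the limit of > 100000 nM in this assay, at which 3 of the 3 values shown sit.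

Compound 4 `Cc1ccc(-c2nn(-c3ccccc3)cc2CNc2ccccc2)cc1` differs from compound 3 in one place, (hydrogen in place of bromo on an aromatic carbon), with hydrogen in place of bromo on an aromatic carbon, para to a large group.

Going by the values given here, two measured steps bear on this: a step that the two limits leave unreadable from compound 1 to compound 3 and a step that the two limits leave unreadable from compound 2 to compound 3. Neither gives a size.

The expectation rests on the limit of compound 3, > 100000 nM. The estimated step is a number no higher from compound 3 to compound 4 (the limit leaves the size open), with no change expected beyond the scatter in this assay. Compound 4 is estimated at 100000 nM, with an expected range of 50000 nM to 200000 nM.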

Compound 4, half-maximal cytotoxic concentration: > 100000 nM
Compound 4 gave a limit, no number (the forecaster's own chance of this, stated with the estimate: 85%); the middle value sits exactly at the limit.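

Compound 4 gives > 100000 nM, a limit and not a number. The steps to it from compound 2 and compound 3 join limit to limit, so no size can be read. The compounds shown leave open how much of any of them is tolerated: the limit of > 100000 nM in this assay, at which 4 of the 4 values shown sit.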